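This account rests on a few compounds, and the source may have more. Where it says the series, first, only, none or still open, it means among the compounds named here.

Compound 1, `O=C(Nc1ccc(Cl)c(-c2nnc3c(Cl)cccn23)c1)c1ccc(F)cc1Cl`, is reported in a functional assay on U-251 cells (Homo sapiens) for antiproliferative activity, read by MTT assay, with a stated time of 72 h (a lower number here means a stronger inhibitor, a higher number a weaker inhibitor), only as a limit of the assay, > 100000 nM.
Compound 2, `Cc1cc(Cl)ccc1C(=O)Nc1ccc(Cl)c(-c2nnc3c(Cl)cccn23)c1`, is likewise reported only as a limit, > 100000 nM.
Compound 3, `O=C(Nc1ccc(Cl)c(-c2nnc3c(Cl)cccn23)c1)c1ccc(Cl)cc1Cl`, is also reported only as a limit, > 100000 nM.

All three measured compounds therefore share the same standing: each sits at the limit of > 100000 nM in this assay, at which 3 of the 3 values shown sit, and no ranking among them can be read. The steps between them are accordingly blank: a step that the two limits leave unreadable from compound 1 to compound 2, a step that the two limits leave unreadable from compound 1 to compound 3 and a step that the two limits leave unreadable from compound 2 to compound 3 all hide their size behind the two limits. Compound 3 stands where its two neighbours stand, with no number of its own.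

Compound 4, `CS(=O)(=O)c1cccc(C(=O)Nc2ccc(Cl)c(-c3nnc4c(Cl)cccn34)c2)c1`, carries the change (3-(methylsulfonyl)phenyl in place of 2,4-dichlorophenyl on a carbonyl carbon). The steps that reach compound 3 from compound 1 and from compound 2 both bear on this change, but neither has a readable size, so they give no direction to expect for compound 4 in this assay. Going by the values given here, the three measured compounds show only that the shared core with three different aryl amides stays at the limit.

The expectation for compound 4 is therefore that it most likely remains at a limit as well, with an estimated value of 150000 nM, ranging from 20000 nM to 1000000 nM, which corresponds to an expected step that the limit leaves unreadable from compound 3 to compound 4.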

Compound 4, half-maximal inhibitory concentration: > 100000 nM
Compound 4: a limit, no number (the forecaster's own chance of this, stated with the estimate: 70%); the middle value is on the limit's open side.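

Compound 4, like compound 1, compound 2 and compound 3, is reported in this assay only as a limit, so none of the steps reaching it can be read: the limit of > 100000 nM in this assay, at which 4 of the 4 values shown sit.

The compounds shown leave open whether any amide on the shared core gives a measurable value in this assay, and how large the effect of any of these changes is.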